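The source may report more compounds than this note shows. Statements on the series, on what has been measured and on what is new or still open speak of the compounds shown alone.

In an ADME assay on L6 cells (Rattus norvegicus) for cytotoxicity, read by resazurin assay, with a stated time of 70 h (a lower number here means a stronger inhibitor, a higher number a weaker inhibitor), compound 1 `CC(=O)Oc1ccc2c(c1)C(C)=CC(C)(C)N2Cc1ccc(C#N)cc1` gives 29000 nM and compound 2 `COc1cc(OC)cc(C(=O)Oc2ccc3c(c2)C(C)=CC(C)(C)N3Cc2ccccc2)c1` gives 24000 nM, so these two stand level within the scatter. Compound 3 `COc1cc(OC)cc(C(=O)Oc2ccc3c(c2)C(C)=CC(C)(C)N3Cc2ccc(Cl)cc2)c1` is reported only as a limit of the assay, > 190000 nM. Compound 4 `CC1=CC(C)(C)N(Cc2ccccc2)c2ccc(OC(=O)C3CCCCC3)cc21` differs from compound 2 at one place: cyclohexyl in place of 3,5-dimethoxyphenyl on a carbonyl carbon. Within the data shown here, the only measured step, an at least 7.9-fold higher number from compound 2 to compound 3 (0.89 log units; beyond the scatter), is chloro in place of hydrogen on an aromatic carbon, is measured against a limit, and does not touch the carbonyl carbon, so it says little about this change. The closer guide is compound 1 at 29000 nM, which carries a different group on that carbonyl carbon yet lies within the scatter of compound 2. In this assay, the expected change is therefore none beyond the scatter, and the estimated step is a 1.2-fold higher number from compound 2 to compound 4 (0.07 log units; within the scatter). Among the measured compounds shown here, the range is kept wide, since no measured step replaces 3,5-dimethoxyphenyl alone. For compound 4 the estimated value is 28000 nM, with an expected range from 8000 nM to 100000 nM.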

Compound 4, half-maximal inhibitory concentration: > 230000 nM
Compound 4 was reported as a limit; the forecaster's own chance of this, stated with the estimate: 15%; middle value at least 8.2-fold (0.91 log units) from the limit.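

In this assay, among these compounds, cyclohexyl in place of 3,5-dimethoxyphenyl on a carbonyl carbon gives an at least 9.5-fold higher number from compound 2 to compound 4 (0.98 log units; beyond the scatter), the only measured step at this position. Among the compounds shown here, compound 4 is reported only as a limit of the assay, so this step gives a lower bound and its full size stays unknown because of that limit: the limit of > 230000 nM in this assay, at which 1 of the 4 values shown sits. The step shows that the group on this carbonyl carbon does bear on the read-out, which the earlier compounds, with no measured step at this position, could not show.

From the compounds shown here alone, what stays open is whether the aromatic ring or the two methoxy groups of the leaving group carry the step, a question that an unsubstituted phenyl on this carbonyl carbon would separate. The compounds shown also do not tell how a longer alkyl chain or an amine at this place would read.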